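One double bond added to a long side chain

The source may hold more compounds than are shown below. What is called first, only, known or untested is meant among the compounds shown, and "the series" means these compounds.

Measured so far:
compound 1 `CCCCCCCCCCCCCCCCCCc1c(O)cc(O)c(C(C)=O)c1O`: 32000 nM
compound 2 `CCCCCCCC/C=C\CCCCCCCCOc1cc(O)c(C(C)=O)c(OCCCCCCCC/C=C\CCCCCCCC)c1`: > 100000 nM, a limit of the assay, not a number

Going by the values given here, in a functional assay on A549 cells (Homo sapiens) for cytotoxicity, read by XTT assay, with a stated time of 72 h (a higher number here means a weaker inhibitor, a lower number a stronger inhibitor), compound 1 gives 32000 nM, and this is the only actual number among the two values. Compound 2 reports only a limit (the limit of > 100000 nM in this assay, at which 1 of the 2 values shown sits), so it cannot be ranked against compound 1 beyond saying that it gave no number. Compound 3 `CCCCCCCC/C=C\CCCCCCCCc1c(O)cc(O)c(C(C)=O)c1O` keeps the core of compound 1 and changes only the chain: dec-1-en-1-yl in place of decyl on a saturated chain carbon, eight bonds along the chain from an aromatic carbon. Among the compounds with values here, no measured pair here tests such a change, so the expectation rests on compound 1 alone. A single double bond far out along a long chain is expected to leave this assay little moved, with no step beyond the usual scatter. Compound 3 is therefore expected to give 30000 nM, in the range 10000 nM to 90000 nM. The expected step of a 1.1-fold lower number from compound 1 to compound 3 (0.03 log units; within the scatter) is estimated to lie within the scatter.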

Compound 3, half-maximal inhibitory concentration: > 100000 nM
Compound 3: a limit, no number; the forecaster's own chance of this, stated with the estimate: 15%; middle value at least 3.3-fold (0.52 log units) from the limit.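

Going by these compounds alone, compound 1 and compound 3 are the first pair here that differ in one place, so this is the first direct test of the chain itself. In this assay, dec-1-en-1-yl in place of decyl gives an at least 3.1-fold higher number from compound 1 to compound 3 (0.49 log units; beyond the scatter), which shows that a single double bond eight bonds along the chain from an aromatic carbon can weaken the compound, even though the chain keeps its carbon count. Compound 3 reports only a limit of the assay, not a number, so the full size of this step cannot be read: the limit of > 100000 nM in this assay, at which 2 of the 3 values shown sit.

One pair cannot show whether the double bond would have the same effect elsewhere along the chain. A triple bond at this place, a shorter chain, or a carboxylic acid at the chain end would each test how far this finding extends.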